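Replacing 2-oxoimidazolidin-1-yl with 4-methyl-1H-imidazol-2-yl

The source may hold more compounds than are shown below. What is called first, only, known or untested is meant among the compounds shown, and "the series" means these compounds.

Of the compounds shown here, two have been measured in an ADME assay on microsomes from liver (Homo sapiens) for metabolic stability; on this read-out lower numbers stand for a shorter-lived compound and higher numbers for a longer-lived compound. Compound 1 `CC(C)C(c1ccc(-c2ccc3cccc(F)c3c2)[nH]c1=O)N1CCCCS1(=O)=O` gives 0.373 h and compound 2 `CC(C)C(c1ccc(-c2ccc3cccc(F)c3c2)[nH]c1=O)N1CCNC1=O` gives 1.03 h and so holds the higher of the two numbers. Compound 3 `Cc1c[nH]c(C(c2ccc(-c3ccc4cccc(F)c4c3)[nH]c2=O)C(C)C)n1` differs from compound 2 in one group: 4-methyl-1H-imidazol-2-yl in place of 2-oxoimidazolidin-1-yl on a saturated chain carbon bound to an aromatic carbon and a saturated chain carbon. For the measured compounds named here, one measured step bears on this place: a 2.8-fold higher number from compound 1 to compound 2 (0.44 log units; beyond the scatter) (modest, and beyond the scatter). It involves a different pair of groups, so it suggests a size but not a direction. Going by the values given here, no aromatic group has yet been measured here. A change no larger than that step is expected, leaning lower from the higher of the two numbers. The expected change is a 1.3-fold lower number from compound 2 to compound 3 (0.11 log units; within the scatter) (an estimate). Compound 3 is estimated at 0.8 h (expected range 0.3 h to 2 h).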

Compound 3, half-life: 0.09 h
The estimate for compound 3 lay 8.9-fold (0.95 log units) above the measured number, and the stated range ends above it.
By their numbers in this assay, from the lowest: compound 3; then compound 1; then compound 2.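

In this assay, for the compounds shown here, the first aromatic group at this saturated chain carbon, 4-methyl-1H-imidazol-2-yl, gives an 11-fold lower number from compound 2 to compound 3 (1.06 log units; beyond the scatter) in place of 2-oxoimidazolidin-1-yl. The same group also gives a 4.1-fold lower number from compound 1 to compound 3 (0.62 log units; beyond the scatter) against the six-membered ring of compound 1, which leaves compound 3 the lowest of the three, with both steps beyond the scatter. The position therefore allows a larger swing than the earlier step showed, even between two groups of equal heavy-atom count, and nothing at hand explains the fall.

Going by these compounds, it remains open whether the fall goes with the aromatic ring itself or with its methyl group. An imidazol-2-yl ring without the methyl, or a pyridine ring at the same carbon, would separate these two readings.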